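Removing the butyl chain from an aziridine urea

A few compounds are considered here, and "the series" means these few. Any claim that something is new, unique, unknown or untested is made for them only; others in the source may bear on it.

Measured so far:
- Compound 1, `N#CC1CN1C(=O)Nc1ccc(Cl)c(Cl)c1`: 7200 nM
- Compound 2, `CCCCNC(=O)N1CC1C#N`: 12000 nM
- Compound 3, `N#CC1CN1C(=O)Nc1ccc([N+](=O)[O-])cc1`: 2600 nM

All three compounds share a small core: a three-membered nitrogen ring carrying a nitrile, with a urea attached to the ring nitrogen. They were tested in a functional assay on L1210 cells (Mus musculus) for inhibition, read by MTT assay; on this read-out higher numbers stand for weaker inhibition and lower numbers for stronger inhibition. Of the three numbers, compound 2 gives the highest one, 12000 nM. Its nearest neighbour is compound 1, whose value of 7200 nM lies within the usual scatter of compound 2, so no order between those two can be read. Compound 3, with 2600 nM, lies beyond the scatter, so compound 3 inhibits more strongly than compound 2 in this assay.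

The unmeasured compound 4, `N#CC1CN1C(N)=O`, differs from compound 2 in one place: hydrogen in place of butyl on an amide-type nitrogen. The urea thus loses its only substituent on that nitrogen and becomes a bare primary urea. For the measured compounds named here, no step between measured compounds tells how this change plays out, and none of the measured compounds carries a hydrogen there. Going by the values given here, since the butyl chain is the only group in compound 2 beyond the shared core, taking it away is expected to give a weaker or, at best, similar inhibitor. Compound 4 is therefore estimated at 20000 nM, with a range from 7000 nM to 60000 nM. This expected step, a 1.7-fold higher number from compound 2 to compound 4 (0.22 log units; within the scatter), is a modest rise toward weaker inhibition.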

Compound 4, half-maximal inhibitory concentration: > 90000 nM
Compound 4 was reported as a limit; the forecaster's own chance of this, stated with the estimate: 20%; at least 4.5-fold (0.65 log units) between middle value and limit.
By their numbers in this assay, from the lowest: compound 3; then compounds 1 and 2 (each within the scatter of the next). At a limit, above all of these: compound 4.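

In this assay, hydrogen in place of butyl on an amide-type nitrogen gives an at least 7.5-fold higher number from compound 2 to compound 4 (0.87 log units; beyond the scatter), so this change weakens inhibition, and by more than the usual scatter of the assay. Compound 4 is reported as a limit and not as a number: the limit of > 90000 nM in this assay, at which 1 of the 4 values shown sits. Every earlier compound carries a group on this nitrogen, so none of them could show that the shared core with only hydrogen there falls this far behind compound 2 in this assay, and that the group at this place matters for the read-out.

For the compounds shown here, with butyl and hydrogen as the only pair compared at this place, it remains open how much of the chain is needed, and whether a shorter chain such as methyl or ethyl, or a longer chain such as octyl, would hold, lose or improve on the inhibition of compound 2. From the compounds shown here alone, it also remains open whether a chain is needed at all, or whether a benzyl group or a hydroxyethyl chain on the same nitrogen would serve as well.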